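Swapping the Methylphenyl for a Fluorophenyl on the Amide

The source may hold more compounds than are shown below. What is called first, only, known or untested is meant among the compounds shown, and "the series" means these compounds.

Going by the values given here, compound 3 `Cc1cccc(NC(=O)CSc2nnc(-c3ccoc3C)n2Cc2ccco2)c1` is the only one of three close analogues to yield a number in a functional assay on CHO cells for antagonist activity at Orexin/Hypocretin receptor type 1 (Homo sapiens), read by FLIPR and calcium flux (a higher number here means a weaker inhibitor, a lower number a stronger inhibitor), where compound 3 gives 2510 nM. Compound 1 `Cc1cccc(C)c1NC(=O)CSc1nnc(-c2ccoc2C)n1Cc1ccco1` reaches only a limit of the assay, > 15800 nM. Compound 2 `Cc1ccc(NC(=O)CSc2nnc(-c3ccoc3C)n2Cc2ccco2)cc1`, which carries a 4-methylphenyl, likewise reaches only a limit, > 15800 nM. The steps of an at least 6.2-fold lower number from compound 1 to compound 3 (0.79 log units; beyond the scatter) and an at least 6.2-fold lower number from compound 2 to compound 3 (0.79 log units; beyond the scatter) both favour the 3-methylphenyl. Compound 4 `Cc1occc1-c1nnc(SCC(=O)Nc2ccc(F)cc2)n1Cc1ccco1` differs from compound 3 in that (4-fluorophenyl in place of 3-methylphenyl on an amide-type nitrogen). Because compound 2 sits at the limit of > 15800 nM in this assay, at which 2 of the 3 values shown sit, a group on the amide nitrogen substituted like the 4-methylphenyl is expected to weaken inhibition, so for compound 4 the step of a 4.0-fold higher number from compound 3 to compound 4 (0.60 log units; beyond the scatter) is estimated. Compound 4 is therefore expected to give about 10000 nM, within 3000 nM to 30000 nM.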

Compound 4, inhibition constant: > 15800 nM
Compound 4: a limit, no number; the forecaster's own chance of this, stated with the estimate: 40%; at least 1.5-fold (0.19 log units) between middle value and limit.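

The change gives an at least 6.2-fold higher number from compound 3 to compound 4 (0.79 log units; beyond the scatter) in this assay, so a 4-fluorophenyl on the amide-type nitrogen does not keep the measurable inhibition seen with the 3-methylphenyl. This change replaces the methyl with fluoro and also alters the substitution pattern, and the data cannot separate those two differences. Among the four groups tried on this nitrogen, only the 3-methylphenyl gives a number: the limit of > 15800 nM in this assay, at which 3 of the 4 values shown sit.

The steps from compound 1 and compound 2 to compound 4 cannot be read, since both ends are limits. As far as these compounds go, how a plain phenyl or a 3-fluorophenyl would behave on this nitrogen remains open.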